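Thioester amides: from carbamoylmethyl ester to primary amide

The source may hold more compounds than are shown below. What is called first, only, known or untested is meant among the compounds shown, and "the series" means these compounds.

Measured in an ADME assay on CEM-SS cells (Homo sapiens) for cytotoxicity, read by XTT assay, with a stated time of 6 days; on this read-out higher numbers stand for lower toxicity in this test and lower numbers for higher toxicity in this test:
compound 1 `CCCC(=O)OCSc1ccccc1C(=O)NCCCCC(N)=O`: 51.7 uM
compound 2 `CCCC(=O)OCSc1ccccc1C(=O)N[C@H]1CCC[C@H]1C(N)=O`: 89.9 uM; 84.8 uM (2 entries)
compound 3 `CCCC(=O)OCSc1ccccc1C(=O)OCC(N)=O`: 82.1 uM

In this assay compound 3 gives 82.1 uM, and the nearest single value belongs to compound 1, with the gap given by a 1.6-fold higher number from compound 1 to compound 3 (0.20 log units; within the scatter). The entries for compound 2 add to this picture, and they agree closely with each other: the several entries of compound 2 in this assay, 89.9 uM; 84.8 uM (2 entries).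

Compound 4 `CCCC(=O)OCSc1ccccc1C(N)=O` is the next step from compound 3, with amino in place of carbamoylmethoxy on a carbonyl carbon whose other neighbours are: aromatic carbon (amino in place of carbamoylmethoxy on a carbonyl carbon).

Going by the values given here, only one measured step bears on this change, since it also exchanges groups on a carbonyl carbon and also involves carbamoylmethoxy: a 1.6-fold higher number from compound 1 to compound 3 (0.20 log units; within the scatter). That step stays small, so no change beyond the scatter is expected, and no direction is favoured with any confidence. Among the compounds with values here, no measured compound carries the small amino group in this place, so the range is kept wide. The expected step is a 1.2-fold lower number from compound 3 to compound 4 (0.07 log units; within the scatter).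

In this assay the estimate for compound 4 is 70 uM, with an expected range from 32 uM to 150 uM.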

Compound 4, half-maximal toxic concentration: 12.4 uM
Estimate against measurement, compound 4: 5.6-fold (0.75 log units) above; measured number outside the range, below it.
By their numbers in this assay, from the lowest: compound 4; then compounds 1 and 3 (each within the scatter of the next).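

In this assay, this carbonyl carbon now shows a step beyond the scatter, which the earlier comparison did not: a 6.6-fold lower number from compound 3 to compound 4 (0.82 log units; beyond the scatter). The same holds when compound 4 is read as the parent of the chain-bearing amide, with hydrogen in place of 4-carbamoylbutyl on an amide-type nitrogen: a 4.2-fold lower number from compound 1 to compound 4 (0.62 log units; beyond the scatter). Carbamoylmethoxy and (4-carbamoylbutyl)amino therefore stay within the scatter of each other, a 1.6-fold higher number from compound 1 to compound 3 (0.20 log units; within the scatter), while the bare amino group alone stands at the more toxic end of these three compounds, and repeat entries in this test agree closely: the several entries of compound 2 in this assay, 89.9 uM; 84.8 uM (2 entries)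

The compounds shown do not separate the contribution of the chain itself from that of its terminal carbamoyl group, a question that a plain butylamino group or a chain ending in a carboxylic acid or an amine would address. They also leave open where along the chain the lower toxicity first appears, from a methylamino group upward, and whether the butyrate-bearing remainder of the shared core takes part in the change.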